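Chain extension on the inactive heptyl member of the series

The compounds below may be only part of what the source reports. "The series", "measured", "known", "first", "only" and "open" are said of these compounds alone.

Compound 1 `CCCCCCCNC[C@@H]1OC[C@H](N)[C@H]1O` reports only a limit in a functional assay on MCF7 cells (Homo sapiens) for antiproliferative activity, read by MTT assay, with a stated time of 72 h (on this read-out higher numbers stand for weaker inhibition and lower numbers for stronger inhibition), > 128000 nM, so its standing among the measured numbers is fixed only by the limit of > 128000 nM in this assay, at which 1 of the 3 values shown sits. Compound 2 `CCCCCCCCCCNC[C@@H]1OC[C@H](N)[C@@H]1O` gives 34200 nM and compound 3 `CCCCCCCCCNC[C@@H]1OC[C@H](N)[C@@H]1O` gives 12500 nM in this assay. Compound 4 `CCCCCCCCCCCCCCNC[C@@H]1OC[C@H](N)[C@H]1O` differs from compound 1 by heptyl in place of hydrogen on a saturated chain carbon, seven bonds along the chain from an amine nitrogen. For the measured compounds named here, the one measured step that concerns chain length, a 2.7-fold lower number from compound 2 to compound 3 (0.44 log units; beyond the scatter), runs toward the shorter chain, so a markedly longer chain would be expected to weaken rather than strengthen inhibition; compound 1 is already beyond the range of the assay. Compound 4 is therefore expected to remain weak, with a fair chance of another limit, and its estimate is 90000 nM, between 25000 nM and 300000 nM, the step of an at least 1.4-fold lower number from compound 1 to compound 4 (0.15 log units; that floor lies within the scatter) being expected only loosely.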

Compound 4, half-maximal inhibitory concentration: 8830 nM
Compound 4: the middle estimate sits 10-fold (1.01 log units) above what was measured; the measured number lies below the stated range.
By their numbers in this assay, from the lowest: compounds 4 and 3 (each within the scatter of the next); then compound 2. At a limit, above all of these: compound 1.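

On the core of compound 1, heptyl in place of hydrogen, seven bonds along the chain from an amine nitrogen, gives an at least 14-fold lower number from compound 1 to compound 4 (1.16 log units; beyond the scatter). Lengthening the chain at this position therefore goes with a lower number, whereas a 2.7-fold lower number from compound 2 to compound 3 (0.44 log units; beyond the scatter) ends on the shorter chain, on a core of different stereochemistry. Compound 1 is only a limit, so the step gives a floor on the size of the change: the limit of > 128000 nM in this assay, at which 1 of the 4 values shown sits.

Still open, going by these compounds, is how a longer chain than that of compound 4 would read on this core. Also open, on these data alone, is whether a terminal hydroxyl on the chain would keep the number of compound 4.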